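This account rests on a few compounds, and the source may have more. Where it says the series, first, only, none or still open, it means among the compounds named here.

Measured compounds in a functional assay on A549 cells (Homo sapiens) for cytotoxicity, read by MTT assay, with a stated time of 48 h; on this read-out higher numbers stand for weaker inhibition and lower numbers for stronger inhibition:
compound 1 `O=c1cc(-c2ccccc2)oc2c(OCCCCNC3CCCCC3)c(O)cc(O)c12`, "not determined" (no result reported)
compound 2 `COc1c(OCCCCN2CCCC2)cc(O)c2c(=O)cc(-c3ccccc3)oc12`, 1530 nM
compound 3 `COc1c(O)cc(O)c2c(=O)cc(-c3ccc(F)cc3)oc12`, "not determined" (no result reported)

Compound 1 has no number of its own in this assay, and the same holds for compound 3, so only compound 2 offers a measured value on the shared core. Compound 4 `CN(C)CCCCOc1c(O)cc(O)c2c(=O)cc(-c3ccccc3)oc12` is obtained from compound 1 by one change: dimethylamino in place of cyclohexylamino on a saturated chain carbon, four bonds along the chain from an oxygen on an aromatic ring. For the measured compounds named here, with no measured pair to anchor this step, no direction can be read from the data; a step of this kind is expected to stay within the usual scatter, or close to it. Resting on the value of compound 2 as the nearest measured relative, compound 4 is estimated at 2000 nM in this assay, with a likely range from 600 nM to 7000 nM.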

Compound 4, half-maximal inhibitory concentration: > 100000 nM
Compound 4: only a limit was reported (the forecaster's own chance of this, stated with the estimate: 10%); at least 50-fold (1.69 log units) between middle value and limit.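

No step can be read between compound 1 and compound 4: compound 1 carries no single number. Compound 4 gives only a limit (> 100000 nM). As far as these compounds go, how swapping cyclohexylamino for dimethylamino shifts cytotoxicity remains open.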